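The compounds below may be only part of what the source reports. "The series", "measured", "known", "first", "only" and "open" are said of these compounds alone.

Of the compounds shown here, three that share one core have been measured in an ADME assay on Vero cells (Chlorocebus sabaeus) for cytotoxicity, read by neutral red uptake, tested at 25 ug/mL; on this read-out lower numbers stand for a stronger effect and higher numbers for a weaker effect at the one concentration tested. Compound 1 `COc1ccc(C2SCC(=O)N2CCN2CCCCC2)cc1` gives 100%, compound 2 `O=C1CSC(c2cccc(Cl)c2)N1CCN1CCCCC1` gives 100%, and compound 3 `O=C1CSC(c2ccc(O)cc2)N1CCN1CCCCC1` gives 100%. Compound 3 therefore stands level with both of its neighbours on the numbers available. Putting hydrogen in place of methyl on an oxygen on an aromatic ring gives no change at the digits printed from compound 1 to compound 3 (within the scatter), and putting 4-hydroxyphenyl in place of 3-chlorophenyl on a saturated ring carbon gives no change at the digits printed from compound 2 to compound 3 (within the scatter); neither change moved the read-out beyond the scatter.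

Compound 4 `O=C1CSC(c2cccc(F)c2)N1CCN1CCCCC1` has not yet been measured. It differs from compound 3 as follows: 3-fluorophenyl in place of 4-hydroxyphenyl on a saturated ring carbon. The most relevant guide is the step that exchanged the whole aromatic group on the same saturated ring carbon, which was no change at the digits printed from compound 2 to compound 3 (within the scatter), and the smaller change on that aromatic group, which was no change at the digits printed from compound 1 to compound 3 (within the scatter). Both were flat, so the step to compound 4 is expected to be no change at the digits printed from compound 3 to compound 4 (within the scatter), that is, nothing beyond the scatter in either direction. Compound 4 is accordingly estimated to give 100% in this assay, with a range from 88% to 100%.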

Compound 4, a percentage reported as activity, at one concentration (the size of the read-out at that concentration, not a potency): 100%
Estimate against measurement, compound 4: no gap at the digits printed, within the range that was stated.
By their numbers in this assay, from the lowest: compounds 1, 2, 3 and 4 (each within the scatter of the next).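

On the saturated ring carbon of the five-membered ring, the entering 3-fluorophenyl carries no hydrogen-bond donor or acceptor, whereas the leaving 4-hydroxyphenyl carries one of each, yet in this assay this exchange gives no change at the digits printed from compound 3 to compound 4 (within the scatter) and so leaves the read-out flat. The new compound also allows a direct comparison of two halogens on an aromatic carbon: fluoro in place of chloro gives no change at the digits printed from compound 2 to compound 4 (within the scatter), so at this one concentration the read-out does not separate the 3-chlorophenyl and 3-fluorophenyl groups. No measurement available here accounts for these flat results.

All four compounds share the same read-out at a single concentration, so the compounds shown do not reveal which change at this position, if any, would lower the number in this assay. Whether an amine or a carboxylic acid on the aromatic ring, or a longer chain in place of the aromatic group, would move the read-out beyond the scatter remains open, as does the behaviour of these compounds at other concentrations.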